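Returning a pyridinyl amide to a series that lost its toxicity

The source may hold more compounds than are shown below. What is called first, only, known or untested is meant among the compounds shown, and "the series" means these compounds.

Three compounds share a common core, shown in compound 1 `COc1ccc(-n2c(SC(C)C(=O)Nc3cc(Br)ccc3Br)nc3ccccc32)cc1`, compound 2 `COc1ccc(-n2c(SC(C)C(=O)Nc3ncc(C(F)(F)F)cc3Cl)nc3ccccc32)cc1` and compound 3 `COc1ccc(-n2c(SC(C)C(=O)Nc3cc(C)no3)nc3ccccc32)cc1`, and differ only in the aryl group on the amide-type nitrogen. In an ADME assay on Vero cells (Chlorocebus sabaeus) for cytotoxicity, read by MTT assay, with a stated time of 24 h (a lower number here means that less compound is tolerated, a higher number that more compound is tolerated), compound 1 gives "not determined" (no result reported). In this assay compound 2 gives 9200 nM. Compound 3 reaches only the limit of this assay, reporting > 75000 nM. That limit, (the limit of > 75000 nM in this assay, at which 1 of the 3 values shown sits), is where compound 3 stands: one of two entries without a single number, and the step of an at least 8.1-fold higher number from compound 2 to compound 3 (0.91 log units; beyond the scatter) is the only measured one.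

Compound 4 `COc1ccc(-n2c(SC(C)C(=O)Nc3ncc(C)cc3Cl)nc3ccccc32)cc1` is not yet measured. It differs from compound 3 by 3-chloro-5-methylpyridin-2-yl in place of 3-methyl-1,2-oxazol-5-yl on an amide-type nitrogen. This change brings back a pyridinyl amide of the kind carried by compound 2, so the step that bears on it is an at least 8.1-fold higher number from compound 2 to compound 3 (0.91 log units; beyond the scatter), read in reverse. Compound 4 is therefore expected to tolerate less than compound 3, a step of an at least 3.7-fold lower number from compound 3 to compound 4 (0.57 log units; beyond the scatter), landing near compound 2. Compound 4 is estimated at 20000 nM, within 6000 nM to 75000 nM.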

Compound 4, half-maximal cytotoxic concentration: 880 nM
The estimate for compound 4 lay 23-fold (1.36 log units) above the measured number; measured number outside the range, below it.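

Bringing back a pyridinyl amide costs far more than the earlier compounds suggested, with an at least 85-fold lower number from compound 3 to compound 4 (1.93 log units; beyond the scatter) in this assay. The pyridinyl amide alone does not set the level either: methyl in place of trifluoromethyl on an aromatic carbon gives a 10-fold lower number from compound 2 to compound 4 (1.02 log units; beyond the scatter), so the group on that ring also counts, and here the smaller change in the group goes with less compound tolerated. The first of these steps rests on a value for compound 3 that is a limit of the assay and not a number: the limit of > 75000 nM in this assay, at which 1 of the 4 values shown sits.

Going by these compounds, it remains open how a nitrile, a methoxy group or an amine on that same aromatic carbon would compare with methyl and trifluoromethyl. On these data alone, it is also open whether a carboxylic acid in place of the methyl on the 3-methyl-1,2-oxazol-5-yl group would leave that compound at the limit.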